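Swapping a phenethyl ether for a fluorophenyl oxolane

A few compounds are considered here, and "the series" means these few. Any claim that something is new, unique, unknown or untested is made for them only; others in the source may bear on it.

Compound 1 `Cc1cc(CCOc2ccc(-c3c(C)nc(C)c([C@H](OC(C)(C)C)C(=O)O)c3N3CCC(C)(C)CC3)cc2)ccc1F` was tested in an ADME assay on microsomes from liver (Homo sapiens) for metabolic stability, read by LC-MS, tested at 0.5 uM; on this read-out higher numbers stand for a longer-lived compound and lower numbers for a shorter-lived compound. In this assay compound 1 gives > 2 h, which is a limit of the assay rather than a number. Two close relatives were measured in the same way. Compound 2 `Cc1nc(C)c([C@H](OC(C)(C)C)C(=O)O)c(N2CCC(C)(C)CC2)c1-c1ccc(OCCc2cc(F)c(F)cc2F)cc1` gives > 2 h, again a limit. Compound 3 `Cc1nc(C)c([C@H](OC(C)(C)C)C(=O)O)c(N2CCC(C)(C)CC2)c1-c1ccc(SCCc2ccc(F)cc2)cc1` gives > 2 h, also a limit. Because every value shown sits at the limit of > 2 h in this assay, at which 3 of the 3 values shown sit, none of the steps between them can be read: the change from compound 1 to compound 2 is a step that the two limits leave unreadable from compound 1 to compound 2, from compound 1 to compound 3 is a step that the two limits leave unreadable from compound 1 to compound 3, and from compound 2 to compound 3 is a step that the two limits leave unreadable from compound 2 to compound 3.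

Compound 4 `Cc1nc(C)c([C@H](OC(C)(C)C)C(=O)O)c(N2CCC(C)(C)CC2)c1-c1ccc(OC2COCC2c2ccc(F)cc2)cc1` is not yet measured. It differs from compound 1 by 4-(4-fluorophenyl)oxolan-3-yl in place of 2-(4-fluoro-3-methylphenyl)ethyl on an oxygen on an aromatic ring. The three measured steps bear on this change only in that every variation of the group on that aromatic oxygen stayed at the limit, so no step beyond the scatter is expected in this assay. Compound 4 is therefore expected to give about 2.5 h, in a range from 1 h to 6 h. The expected step is a step that the limit leaves unreadable from compound 1 to compound 4.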

Compound 4, half-life: 0.783 h
Beside the measured number, compound 4's estimate is 3.2-fold (0.50 log units) above it, and the stated range ends above it.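

In this assay, the group on the oxygen on an aromatic ring proves able to change the read-out: putting 4-(4-fluorophenyl)oxolan-3-yl there gives an at least 2.5-fold lower number from compound 1 to compound 4 (0.40 log units; beyond the scatter) and an at least 2.5-fold lower number from compound 2 to compound 4 (0.40 log units; beyond the scatter). Within the data shown here, compound 4 thus gives the first value here that is a number and not a limit, and both steps are minimum sizes, since the true values of compound 1 and compound 2 cannot be read. The steps among compound 1, compound 2 and compound 3 cannot be read, so those compounds could not show that this position responds to change: the limit of > 2 h in this assay, at which 3 of the 4 values shown sit.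

The compounds shown do not separate the effect of closing the ring from that of the ring oxygen. Among these compounds, a cyclopentyl ring carrying the same 4-fluorophenyl group would address that question, and no line of compounds here shows how the value varies within the oxolane series.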